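A Hydroxyphenyl Swap at the Assay Limit

The compounds below may be only part of what the source reports. "The series", "measured", "known", "first", "only" and "open" are said of these compounds alone.

Going by the values given here, only two compounds have been measured so far in an ADME assay on BJ cells (Homo sapiens) for cytotoxicity, read by MTT assay, with a stated time of 72 h; a higher number here means a weaker inhibitor, a lower number a stronger inhibitor. Compound 1 (`Oc1cccc(CNc2ncnc3c2ncn3C2CCCCO2)c1`) gives > 100000 nM, which is a limit of the assay and not a number. Compound 2 (`Oc1ccccc1CNc1ncnc2c1ncn2C1CCCO1`) gives > 100000 nM, which is also a limit and not an exact number. The position of compound 2 is therefore known only as a limit, and the record so far reads: the limit of > 100000 nM in this assay, at which 2 of the 2 values shown sit.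

Compound 3 (`Oc1cccc(CNc2ncnc3c2ncn3C2CCCO2)c1`) has the same atoms as compound 2, joined differently: 3-hydroxyphenyl in place of 2-hydroxyphenyl on a saturated chain carbon bound to a nitrogen on an aromatic ring. Among the compounds with values here, no measured step is available to show how much such a change matters. With compound 2 at > 100000 nM, the expectation is no step beyond the usual scatter in this assay, and another limit is the most likely report. The estimated change is a number no higher from compound 2 to compound 3 (the limit leaves the size open). For compound 3 the expected value is 100000 nM, with an estimated range of 50000 nM to 200000 nM.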

Compound 3, half-maximal inhibitory concentration: > 100000 nM
Compound 3 gave a limit, no number; the forecaster's own chance of this, stated with the estimate: 85%; the middle value lies on the limit itself.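

No step can be read between compound 3 and either compound 1 or compound 2, because all three report only a limit of the assay: the limit of > 100000 nM in this assay, at which 3 of the 3 values shown sit.

The compounds shown leave open what their exact values are, and whether 3-hydroxyphenyl and 2-hydroxyphenyl, or oxolan-2-yl and oxan-2-yl, make any difference in this assay.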